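Bromo on the quinoline ring of compound 2: expected cytotoxicity

A few compounds are considered here, and "the series" means these few. Any claim that something is new, unique, unknown or untested is made for them only; others in the source may bear on it.

Compound 1 `COc1cc(NC(=O)COc2cc(C)nc3ccc(OC)cc23)cc(OC)c1` — > 131000 nM
Compound 2 `COc1ccccc1NC(=O)COc1cc(C)nc2ccccc12` — 8640 nM

Of the compounds shown here, two have been measured in an ADME assay on HepG2 cells (Homo sapiens) for cytotoxicity, read by trypan blue exclusion, with a stated time of 48 h, in the presence of a further agent that is not named here; a lower number here means that less compound is tolerated, a higher number that more compound is tolerated. For compound 1 the result is a limit of the assay, (the limit of > 131000 nM in this assay, at which 1 of the 2 values shown sits), and not a number. Going by the values given here, compound 2 therefore stands as the only compound with a numerical value, giving 8640 nM in this assay. Among the compounds with values here, because one of the two values is a limit, no step between measured compounds can be drawn, and there is nothing in the data to show how any change to the shared core shifts the read-out.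

Compound 3 `COc1ccccc1NC(=O)COc1cc(C)nc2ccc(Br)cc12` is the next compound to be measured. It differs from compound 2 in one place: bromo in place of hydrogen on an aromatic carbon. Within the data shown here, with no measured step to guide the expectation, a change of this kind is expected to move the half-maximal cytotoxic concentration only modestly, if at all, most likely staying within or close to the usual scatter. The estimated step from compound 2 to compound 3 is a 1.3-fold lower number from compound 2 to compound 3 (0.12 log units; within the scatter). Compound 3 is accordingly expected to give about 6500 nM in this assay, with a plausible range from 2500 nM to 20000 nM.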

Compound 3, half-maximal cytotoxic concentration: > 125000 nM
Compound 3: only a limit was reported; the forecaster's own chance of this, stated with the estimate: 5%; middle value at least 19-fold (1.28 log units) from the limit.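

Bromo in place of hydrogen, on an aromatic carbon of a six-membered aromatic ring of carbon only, gives an at least 14-fold higher number from compound 2 to compound 3 (1.16 log units; beyond the scatter) in this assay, so this single position can move the read-out well beyond the scatter, towards more compound being tolerated, which the earlier compounds, with no step between them, could not show. For compound 3 the result of > 125000 nM is a limit of the assay and not a number, so the step has a lower bound but no known upper end: the limit of > 125000 nM in this assay, at which 1 of the 3 values shown sits. Going by these compounds alone, compound 2, at 8640 nM, thus remains the only one of the three compounds with a numerical value, and the change from hydrogen to bromo is the only structural difference that separates it from compound 3.

The compounds shown leave open whether this shift belongs to bromo in particular or would also follow from chloro, fluoro or an amine on the same aromatic carbon. They also leave open whether bromo at this place would give a step of similar size with a different substitution on the anilide ring.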